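Working notes: chloro in place of bromo on compound 2

This account rests on a few compounds, and the source may have more. Where it says the series, first, only, none or still open, it means among the compounds named here.

Measured so far in a functional assay on HeLa cells (Homo sapiens) for inhibition, read by CCK-8 assay, with a stated time of 72 h, tested at 2 uM; on this read-out lower numbers stand for less inhibition of growth and higher numbers for more inhibition of growth at the one concentration tested
compound 1 `Nc1ccccc1NC(=O)c1ccc(CSc2cccc(F)c2)cc1` gives 22.5%
compound 2 `Nc1ccccc1NC(=O)c1ccc(CSc2ccc(Br)cc2)cc1` gives 18.8%

Compound 2 at 18.8% stands within the scatter of compound 1, so the two cannot be ordered. The change to compound 3 `Nc1ccccc1NC(=O)c1ccc(CSc2ccc(Cl)cc2)cc1` is chloro in place of bromo on an aromatic carbon, para to a large group. Within the data shown here, the only measured step that bears on it is a number 3.7 percentage points lower from compound 1 to compound 2 (within the scatter), which concerns the group on the sulfur and stays within the scatter. Among the measured compounds shown here, no measured pair compares bromo with chloro directly. No step beyond the scatter is therefore expected in this assay, and no direction can be stated. The expected step is a number 1.2 percentage points higher from compound 2 to compound 3 (within the scatter), inside the scatter. For compound 3 the estimated value is 20% with an expected range from 12% to 28%.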

Compound 3, percent growth inhibition at one concentration: 19.2%
Estimate against measurement, compound 3: 0.8 percentage points above; low and high end bracket the measured number.
By their numbers in this assay, from the lowest: compounds 2, 3 and 1 (each within the scatter of the next).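

In this assay, bromo and chloro are now compared directly on an aromatic carbon, para to a large group, and the swap gives a number 0.4 percentage points higher from compound 2 to compound 3 (within the scatter) so the two halogens cannot be told apart at this place. Replacing the group on the sulfur with 4-chlorophenyl in place of 3-fluorophenyl gives a number 3.3 percentage points lower from compound 1 to compound 3 (within the scatter) and so the three compounds still form one group with no order among them. Nothing measured bears on why these numbers lie together.

The compounds shown carry only halogens on the phenyl group attached to the sulfur, so whether an amine, a carboxylic acid or a methoxy group at this place would give a step beyond the scatter stays open. Also open, from the compounds shown here alone, is whether these compounds would stay together across a range of concentrations rather than at the single one tested.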